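The source may report more compounds than this note shows. Statements on the series, on what has been measured and on what is new or still open speak of the compounds shown alone.

Working notes on the series, read-out a physicochemical assay for solubility, measured as kinetic solubility; on this read-out lower numbers stand for lower solubility and higher numbers for higher solubility. Within the data shown here, compound 1 (`COc1ccc(S(=O)(=O)Nc2ccc(CN3C[C@@H]4C[C@H]3CN4C(=O)c3cccc(Cl)c3)cc2)cc1`) gives 47000 nM, the only true number so far. Compound 2 (`COc1ccc(S(=O)(=O)Nc2ccc(CN3CCN(C(=O)C4CN(C(C)=O)C4)CC3)cc2)cc1`) gives >= 511000 nM, which is a limit of the assay and not a number. Compound 2 therefore stands at the top of the values seen, with its real position unknown, and compound 1 holds the lower of the two values.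

Compound 3 (`COc1ccc(S(=O)(=O)Nc2ccc(CN3CCN(C(=O)C4CC(O)(C(F)(F)F)C4)CC3)cc2)cc1`) is still to be measured in this assay. It keeps the core of compound 2 and exchanges one group on the carbonyl carbon: 3-hydroxy-3-(trifluoromethyl)cyclobutyl in place of 1-acetylazetidin-3-yl on a carbonyl carbon. In words, 3-hydroxy-3-(trifluoromethyl)cyclobutyl comes in place of 1-acetylazetidin-3-yl.

Among the measured compounds shown here, no measured step bears on this exchange, so the expectation is a loose one. A fall beyond the scatter is expected, with compound 3 landing closer to compound 1 at 47000 nM. The expected size of the change is an at least 4.2-fold lower number from compound 2 to compound 3 (0.62 log units; beyond the scatter). For compound 3 the estimated value is 120000 nM, with an expected range of 35000 nM to 420000 nM.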

Compound 3, solubility: >= 374000 nM
Compound 3 ended at the assay's limit; the forecaster's own chance of this, stated with the estimate: 15%; at least 3.1-fold (0.49 log units) between middle value and limit.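

In this assay compound 3 gives >= 374000 nM, which is a limit and not a number. Compound 2 gives >= 511000 nM, also a limit. No step can be read between compound 2 and compound 3. The compounds shown leave open where the true values of these two compounds lie, and which of them stands higher.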